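Cyclopropyl on the Amide Nitrogen of a Pyridine Amide

The source may report more compounds than this note shows. Statements on the series, on what has been measured and on what is new or still open speak of the compounds shown alone.

Three compounds share one core. Compound 1 `NNC(=O)COc1ccncc1-c1ccc2ccccc2c1` has "not determined" (no result reported) in an assay on a protein complex for inhibition of CDK8/Cyclin C (Homo sapiens), with a stated time of 1 h; on this read-out lower numbers stand for stronger inhibition and higher numbers for weaker inhibition. Compound 2 `CNC(=O)CCc1ccncc1-c1ccc2ccccc2c1` gives 21.1 nM in this assay. Compound 3 `NC(=O)/C=C/c1ccncc1-c1ccc2ccccc2c1` gives 10.5 nM in this assay, and its number and that of compound 2 lie within the scatter of each other, so neither can be called stronger.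

Compound 4 `O=C(/C=C/c1ccncc1-c1ccc2ccccc2c1)NC1CC1` differs from compound 3 by cyclopropyl in place of hydrogen on an amide-type nitrogen. Among the measured compounds shown here, no measured step changes only the substituent on the amide nitrogen. For the measured compounds named here, the one measured step, a 2.0-fold lower number from compound 2 to compound 3 (0.30 log units; within the scatter), swapped a methyl-bearing amide and a saturated chain for an unsubstituted amide on an unsaturated chain, and it stayed within the scatter. Going by the values given here, that is the only guide, and it suggests that a change at the amide nitrogen does not move the number far.

Compound 4 is therefore expected to give about 10 nM, within a range from 4 nM to 30 nM. The step that this estimate means, a 1.1-fold lower number from compound 3 to compound 4 (0.02 log units; within the scatter), is expected to remain within the scatter.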

Compound 4, half-maximal inhibitory concentration: 40.1 nM
The estimate for compound 4 lay 4.0-fold (0.60 log units) below the measured number; the whole stated range lies below it.
By their numbers in this assay, from the lowest: compounds 3, 2 and 4 (each within the scatter of the next, the first and the last beyond it).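

Cyclopropyl in place of hydrogen on the amide-type nitrogen is the first change shown that alters only this nitrogen, and it has a measurable cost in this assay (a 3.8-fold higher number from compound 3 to compound 4 (0.58 log units; beyond the scatter)), so this position does not accept every group without a loss of inhibition. The wider change to 2-(cyclopropylcarbamoyl)ethenyl in place of 2-(methylcarbamoyl)ethyl on an aromatic carbon stays within the scatter (a 1.9-fold higher number from compound 2 to compound 4 (0.28 log units; within the scatter)), so the loss is seen only against the unsubstituted amide. No measurement here gives a reason for this loss.

The compounds shown leave open whether an ethyl group or a longer chain on the same nitrogen would behave like hydrogen or like cyclopropyl. They also leave open how a carboxylic acid in place of the amide would read.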